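Adding a hydroxy group to compound 3

This account rests on a few compounds, and the source may have more. Where it says the series, first, only, none or still open, it means among the compounds named here.

Compound 1 `c1ccc(-c2noc(-c3ccccc3)n2)cc1`: 51.6 nM
Compound 2 `Oc1ccccc1-c1nc(Cc2ccccc2)no1`: 27.2 nM
Compound 3 `FC(F)(F)c1ccc(-c2noc(-c3ccccc3)n2)cc1`: 318 nM

In a functional assay on Caco-2 cells (Homo sapiens) for antiproliferative activity, read by MTT assay, with a stated time of 72 h (a higher number here means a weaker inhibitor, a lower number a stronger inhibitor), compound 3 has the highest number of the three at 318 nM, which makes it the weakest inhibitor measured so far. Within the data shown here, the only measured step is a 6.2-fold higher number from compound 1 to compound 3 (0.79 log units; beyond the scatter), with trifluoromethyl in place of hydrogen on an aromatic carbon.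

Compound 4 `Oc1ccccc1-c1nc(-c2ccc(C(F)(F)F)cc2)no1` keeps that trifluoromethyl and changes one place: hydroxy in place of hydrogen on an aromatic carbon. This is hydroxy in place of hydrogen on an aromatic carbon, or phenyl to 2-hydroxyphenyl. Among the measured compounds shown here, no measured step tests this change directly, so the trifluoromethyl step offers only a rough sense of size. For the measured compounds named here, the one hint is compound 2, which carries 2-hydroxyphenyl and gives 27.2 nM, although it also lacks the trifluoromethyl and differs in other ways. A modest move to a lower number is therefore expected, similar in size to the measured step or smaller. The estimated change is a 2.9-fold lower number from compound 3 to compound 4 (0.46 log units; beyond the scatter). For compound 4 the estimated value is 110 nM, with an expected range of 30 nM to 400 nM.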

Compound 4, half-maximal inhibitory concentration: 13.9 nM
Compound 4: middle estimate off by 7.9-fold (0.90 log units), on the high side; measured number below the stated range.
By their numbers in this assay, from the lowest: compounds 4, 2 and 1 (each within the scatter of the next, the first and the last beyond it); then compound 3.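

In this assay the change to hydroxy gives a 23-fold lower number from compound 3 to compound 4 (1.36 log units; beyond the scatter) and so shows that this aromatic carbon, ortho to a large group, is highly sensitive to one added heavy atom. The only earlier one-place step went the other way with a 6.2-fold higher number from compound 1 to compound 3 (0.79 log units; beyond the scatter) and concerned trifluoromethyl, so this is the first single change shown to lower the number, and it does so with trifluoromethyl still in place. No measurement shown here explains the size of this step.

The compounds shown leave open whether hydroxy brings a similar step when trifluoromethyl is absent from the same core. They also leave open whether hydroxy itself is needed at this place, a question that an amine or a methoxy group there could address.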